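Trimming the diethylcarbamoyl group from compound 3

The compounds below may be only part of what the source reports. "The series", "measured", "known", "first", "only" and "open" are said of these compounds alone.

In a functional assay for inhibition (on this read-out lower numbers stand for stronger inhibition and higher numbers for weaker inhibition), compound 1 `CN(C)CCCOc1ccc2c(=O)cc(-c3cc(C(C)(C)C)c(O)c(C(C)(C)C)c3)oc2c1` gives 700 nM as its reading. Compound 2 `CC(C)(C)c1cc(-c2cc(=O)c3ccc(OCC(=O)N4CCCCC4)cc3o2)cc(C(C)(C)C)c1O` stands at 3000 nM and compound 3 `CCN(CC)C(=O)COc1ccc2c(=O)cc(-c3cc(C(C)(C)C)c(O)c(C(C)(C)C)c3)oc2c1` stands at 3000 nM on the same read-out. Compound 3 is thus level with compound 2, and the two share the highest number of the three.

Compound 4 `COc1ccc2c(=O)cc(-c3cc(C(C)(C)C)c(O)c(C(C)(C)C)c3)oc2c1` has not been measured yet. It carries hydrogen in place of diethylcarbamoyl on a saturated chain carbon bound to an oxygen on an aromatic ring, so (diethylcarbamoyl)methoxy becomes methoxy.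

Among the measured compounds shown here, three measured steps concern this same place. Exchanging piperidin-1-yl for diethylamino on the carbonyl carbon gave no change at the digits printed from compound 2 to compound 3 (within the scatter) as its result. Replacing 2-(dimethylamino)ethyl with a carbonyl-bearing group gave a 4.3-fold higher number from compound 1 to compound 2 (0.63 log units; beyond the scatter) in one case and a 4.3-fold higher number from compound 1 to compound 3 (0.63 log units; beyond the scatter) in the other, both modest. Going by these compounds, none of these steps removes the group altogether, so the direction remains open. In this assay a step no larger than these modest ones is expected, with a slight lean toward a lower number. That lean rests on compound 1 at 700 nM which has no carbonyl at this place. The expected change is a 1.5-fold lower number from compound 3 to compound 4 (0.18 log units; within the scatter) and it remains uncertain. For compound 4 the estimate is 2000 nM with an expected range from 600 nM to 6000 nM on this read-out.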

Compound 4, half-maximal inhibitory concentration: 1000 nM
For compound 4 the middle estimate is 2.0-fold (0.30 log units) above the measured one; low and high end bracket the measured number.
By their numbers in this assay, from the lowest: compounds 1 and 4 (each within the scatter of the next); then compounds 2 and 3 (each within the scatter of the next).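

In this assay, taking the diethylcarbamoyl group away so that only methoxy remains gives a 3.0-fold lower number from compound 3 to compound 4 (0.48 log units; beyond the scatter), and taking away (piperidin-1-yl)carbonyl gives a 3.0-fold lower number from compound 2 to compound 4 (0.48 log units; beyond the scatter), so the two carbonyl-bearing groups read worse than having no such group at all. The other comparison, a 1.4-fold higher number from compound 1 to compound 4 (0.15 log units; within the scatter), stays within the scatter, so the chain ending in dimethylamino cannot be told apart from plain methoxy, and the gap seen earlier between compound 1 and the two carbonyl-bearing compounds now reads as a penalty tied to those two groups rather than a gain from the amine. Nothing measured here explains why these two groups go with the higher numbers.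

The compounds shown leave open whether any group at this place can bring the number clearly below that of compound 4, for example a longer plain alkyl chain or a chain ending in a cyclic amine such as morpholine. They also leave open whether the penalty extends to a carboxylic acid on the same chain carbon, or to a carbonyl-bearing group whose nitrogen keeps its hydrogen, such as a primary amide.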